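Ethoxycarbonyl to carbamoyl on the shared core

A few compounds are considered here, and "the series" means these few. Any claim that something is new, unique, unknown or untested is made for them only; others in the source may bear on it.

Compound 1 (`CCOC(=O)/C=C/c1ccncc1-c1ccc2ccccc2c1`) is the starting point of this step. In a functional assay on KB cells (Homo sapiens) for inhibition, read by sulforhodamine B assay, with a stated time of 72 h (on this read-out higher numbers stand for weaker inhibition of growth and lower numbers for stronger inhibition of growth), compound 1 gives > 10000 nM as a limit of the assay and not a number. Within the data shown here, compound 2 (`CCOC(=O)/C=C/c1ccncc1-c1ccc2cc[nH]c2c1`) carries the same 2-(ethoxycarbonyl)ethenyl group on a different core, and in this assay compound 2 gives 7860 nM as the only actual number so far. Among the measured compounds shown here, the position of the series is thus the limit of > 10000 nM in this assay, at which 1 of the 2 values shown sits, and no measured step links the two compounds.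

Compound 3 (`NC(=O)/C=C/c1ccncc1-c1ccc2ccccc2c1`) keeps the core of compound 1 and changes one group (amino in place of ethoxy on a carbonyl carbon): amino in place of ethoxy on a carbonyl carbon, which also reads ethoxycarbonyl to carbamoyl. For the measured compounds named here, no measured pair shows this change, so the expectation is loose. In this assay no step beyond the scatter is expected, with growth inhibition staying weak, as for compound 2 at 7860 nM in the same range. The estimated change is a number no higher from compound 1 to compound 3 (the limit leaves the size open) and no more than that is expected. For compound 3 the estimate is 10000 nM with an expected range of 4000 nM to 25000 nM in repeated measurements.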

Compound 3, concentration for 50% growth inhibition: > 10000 nM
Compound 3: no number, only a limit (the forecaster's own chance of this, stated with the estimate: 55%); the middle value sits exactly at the limit.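

In this assay compound 3 gives > 10000 nM, a limit of the assay and not a number. Compound 1 also stands at a limit, so no step can be read between compound 1 and compound 3. The compounds shown leave open whether amino in place of ethoxy on a carbonyl carbon changes growth inhibition at all, with the series still resting on one boundary: the limit of > 10000 nM in this assay, at which 2 of the 3 values shown sit.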